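A few compounds are considered here, and "the series" means these few. Any claim that something is new, unique, unknown or untested is made for them only; others in the source may bear on it.

Measured compounds:
Compound 1, `CCO/N=C1/C(=O)N(Cc2cn(CC(=O)N3CCN(c4cc5c(cc4F)c(=O)c(C(=O)O)cn5C4CC4)CC3)nn2)c2ccc(C)cc21`: 32 ug/mL
Compound 2, `CCO/N=C1/C(=O)N(Cc2cn(CC(=O)N3CCN(c4cc5c(cc4F)c(=O)c(C(=O)O)cn5C4CC4)CC3)nn2)c2ccccc21`: 64 ug/mL
Compound 3, `O=C1C(=O)N(Cc2cn(CC(=O)N3CCN(c4cc5c(cc4F)c(=O)c(C(=O)O)cn5C4CC4)CC3)nn2)c2ccccc21`: 16 ug/mL

These three compounds were tested in an ADME assay on Vero cells (Chlorocebus sabaeus) for cytotoxicity; on this read-out lower numbers stand for higher toxicity in this test and higher numbers for lower toxicity in this test. Compound 2 gives 64 ug/mL in this assay, compound 1 gives 32 ug/mL, and compound 3 gives 16 ug/mL. Compound 3 has the lowest of the three numbers; its gap to compound 2 is beyond the scatter, while its gap to compound 1 is within it.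

Compounds 1 and 2 share a core and differ in one place: methyl in place of hydrogen on an aromatic carbon. That change gave a 2.0-fold lower number from compound 2 to compound 1 (0.30 log units; within the scatter).

Compound 4, `Cc1ccc2c(c1)C(=O)C(=O)N2Cc1cn(CC(=O)N2CCN(c3cc4c(cc3F)c(=O)c(C(=O)O)cn4C3CC3)CC2)nn1`, has not yet been measured in this assay. It is built from compound 3 by the same change: methyl in place of hydrogen on an aromatic carbon. The difference between the two cores, that of compound 2 and that of compound 3, is not broken down here.

Because the step of a 2.0-fold lower number from compound 2 to compound 1 (0.30 log units; within the scatter) lies within the scatter, the expectation for compound 4 is a number close to that of compound 3, perhaps somewhat lower. For compound 4 the expected step is a 1.3-fold lower number from compound 3 to compound 4 (0.12 log units; within the scatter). Compound 4 is therefore estimated to give 12 ug/mL in this assay, with a likely range from 5 ug/mL to 30 ug/mL. This rests on one measured pair only, so the estimate is uncertain.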

Compound 4, half-maximal cytotoxic concentration: 16 ug/mL
For compound 4 the middle estimate is 1.3-fold (0.12 log units) below the measured one; the measured number falls inside the stated range.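

In this assay, putting methyl in place of hydrogen on an aromatic carbon of the core of compound 3 gave no change at the digits printed from compound 3 to compound 4 (within the scatter). Set beside the same change on the core of compound 2, the two results cannot be told apart, so on this read-out the change carries from one core to the other without any visible difference: the same change on two cores in this assay, a 2.0-fold lower number (0.30 log units; within the scatter) from compound 2 to compound 1 and no change at the digits printed (within the scatter) from compound 3 to compound 4, 2.0-fold (0.30 log units) apart, within the scatter of two such steps This does not show that the methyl has a real effect on either core, nor that the two cores respond in exactly the same way, since neither step rises above the normal spread of repeated measurements and only two pairs are available, so a small effect could go unseen.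

The compounds shown leave open what a different group on that same aromatic carbon would do, such as a chlorine atom, a methoxy group or an amine, and whether any of these would move the number by more than the scatter. They also leave open whether the methyl would behave the same way on a core other than these two, or in a test other than this cell-toxicity measurement.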